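The source may hold more compounds than are shown below. What is called first, only, known or untested is meant among the compounds shown, and "the series" means these compounds.

Measured in a physicochemical assay for solubility; a lower number here means a less soluble compound, a higher number a more soluble compound:
Compound 1 `CNC(=O)c1cc(C(=O)NCCC[C@H]2OC[C@H](N)CO2)cc2c1O[C@H](CF)[C@H]2c1ccccc1`: 174 ug/mL
Compound 2 `CNC(=O)c1cc(C(=O)NC)c2c(c1)[C@H](c1ccccc1)[C@@H](CF)O2`: >= 149 ug/mL, a limit of the assay

Compound 2 stands at the limit of >= 149 ug/mL in this assay, at which 1 of the 2 values shown sits, so its place is known only as a limit and not as a number. Compound 3 `CNC(=O)c1cc(C(=O)NC2CC2)cc2c1O[C@H](CF)[C@H]2c1ccccc1` departs from compound 2 by a single change, cyclopropyl in place of methyl on an amide-type nitrogen.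

The data offer little to judge this change by. Among the measured compounds shown here, the only measured step is a step that the limit leaves unreadable from compound 1 to compound 2. That step swaps a different group, on a saturated chain carbon rather than on the amide-type nitrogen, and its size cannot be read. For the measured compounds named here, no measured step therefore bears on the exchange of methyl for cyclopropyl, and none gives it a direction. With no evidence for a shift, no step beyond the scatter is expected in this assay. The expected step is a step that the limit leaves unreadable from compound 2 to compound 3. For compound 3 the estimated value is 150 ug/mL, with an expected range from 70 ug/mL to 200 ug/mL.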

Compound 3, solubility: 8 ug/mL
Beside the measured number, compound 3's estimate is 19-fold (1.27 log units) above it, and the stated range ends above it.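

In this assay, among the compounds shown here, the amide-type nitrogen now shows a readable step for the first time: cyclopropyl in place of methyl gives an at least 18-fold lower number from compound 2 to compound 3 (1.27 log units; beyond the scatter), so an exchange of so few atoms at this place is enough to move the number well beyond the scatter. Compound 1 carries a far larger group on the same nitrogen, with a six-membered non-aromatic ring, and replacing that group with cyclopropyl gives a 22-fold lower number from compound 1 to compound 3 (1.34 log units; beyond the scatter), so compound 3 stands well under compound 1 as well. The step from compound 1 to compound 2 cannot be read, and compound 2 is known only as a limit: the limit of >= 149 ug/mL in this assay, at which 1 of the 3 values shown sits.

The compounds shown leave open whether the large step follows the three-membered ring itself or simply the added carbon atoms, since an ethyl or an isopropyl group on this nitrogen would separate the two readings. They also leave open whether a short chain ending in an amine, on the same nitrogen, would stand nearer compound 1 or nearer compound 3 in this assay, and they give no cause for the step.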